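A few compounds are considered here, and "the series" means these few. Any claim that something is new, unique, unknown or untested is made for them only; others in the source may bear on it.

Measured in a functional assay on A549 cells (Homo sapiens) for antiproliferative activity, read by MTT assay, with a stated time of 72 h; on this read-out lower numbers stand for stronger inhibition and higher numbers for weaker inhibition:
compound 1 `CCC/C=C/C(=O)Nc1cccc(Oc2nc(Nc3ccn(C)n3)nc3c2CSCC3)c1` gives 8190 nM
compound 2 `C=CC(=O)Nc1cccc(Oc2nc(Nc3cccc(OC)c3)nc3c2CSCC3)c1` gives 10100 nM
compound 3 `CC/C=C/C(=O)Nc1cccc(Oc2nc(Nc3cccc(OC)c3)nc3c2CSCC3)c1` gives 17200 nM

Compound 3 stands at the upper end of these numbers, level within the scatter with compound 2, while its gap to compound 1 lies just beyond the scatter. Compound 4 `CCC/C=C/C(=O)Nc1cccc(Oc2nc(Nc3cccc(OC)c3)nc3c2CSCC3)c1` extends its but-1-en-1-yl to pent-1-en-1-yl, with methyl in place of hydrogen on a saturated chain carbon, two bonds along the chain from a double-bonded chain carbon. Among the measured compounds shown here, the only measured step on this chain, vinyl to but-1-en-1-yl, is a 1.7-fold higher number from compound 2 to compound 3 (0.23 log units; within the scatter). So no step beyond the scatter is expected in this assay. The expected step is a 1.1-fold lower number from compound 3 to compound 4 (0.03 log units; within the scatter). For compound 4 the estimate is 16000 nM, with an expected range of 8000 nM to 32000 nM.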

Compound 4, half-maximal inhibitory concentration: 11800 nM
Beside the measured number, compound 4's estimate is 1.4-fold (0.13 log units) above it; measured number inside the range.
By their numbers in this assay, from the lowest: compounds 1, 2, 4 and 3 (each within the scatter of the next, the first and the last beyond it).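

In this assay, pent-1-en-1-yl on the carbonyl carbon gives a 1.5-fold lower number from compound 3 to compound 4 (0.16 log units; within the scatter) and a 1.2-fold higher number from compound 2 to compound 4 (0.07 log units; within the scatter), so the chain stays level with both shorter ones at this position, with each step within the scatter. Among the compounds shown here, the first comparison at the group on the nitrogen gives a 1.4-fold higher number from compound 1 to compound 4 (0.16 log units; within the scatter), also within the scatter, so 3-methoxyphenyl and 1-methyl-1H-pyrazol-3-yl read alike with this chain in place. Nothing available explains these steps. Still open, as far as these compounds go, is whether a chain ending in a dimethylamino group, or a longer hept-1-en-1-yl chain, would move the number beyond the scatter.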